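The source may hold more compounds than are shown below. What is called first, only, known or untested is meant among the compounds shown, and "the series" means these compounds.

Measured so far:
compound 1, `CCCCCCCCCCc1ccc(-c2noc(CC3CNC3)n2)cc1`: 63%
compound 2, `CCCCCCCCCCc1ccc(-c2noc(C3CCNCC3)n2)cc1`: 66%
compound 3, `CCCCCCCCCCc1ccc(-c2noc([C@@H]3CC[C@H](N)C3)n2)cc1`: 38%

In an assay on HeLa cells for inhibition of sphingosine-1-phosphate transporter SPNS2 (Mus musculus), read by LC-MS, tested at 2 uM (a higher number here means more inhibition at the concentration tested (going by the name of the read-out), a lower number less inhibition), compound 1 holds the second highest of the three numbers. The step of a number 3 percentage points higher from compound 1 to compound 2 (within the scatter) lies within the scatter, whereas a number 25 percentage points lower from compound 1 to compound 3 (beyond the scatter) and a number 28 percentage points lower from compound 2 to compound 3 (beyond the scatter) are modest losses. Compound 4, `CCCCCCCCCCc1ccc(-c2noc(CC(CN)OC(C)=O)n2)cc1`, differs from compound 1 by a group of 7 heavy atoms (4 carbon, 1 nitrogen, 2 oxygen; no ring) in place of a group of 4 heavy atoms (3 carbon, 1 nitrogen; one four-membered non-aromatic ring with 1 hetero atom), on a saturated chain carbon bound to an aromatic carbon. For the measured compounds named here, the step that bears on it most is compound 1 to compound 3, where a primary amine on a ring replaced the cyclic secondary amine and inhibition fell modestly; compound 4 likewise carries a primary amine, but on an open chain with an acetate, and no measured step covers the loss of the ring or the added ester. A loss of about a number 28 percentage points lower from compound 1 to compound 4 (beyond the scatter) is therefore expected for compound 4. Compound 4 is estimated at 35%, in a range from 10% to 60%.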

Compound 4, a percentage reported as inhibition, at one concentration (the size of the read-out at that concentration, not a potency): 0%
The estimate for compound 4 lay 35 percentage points above the measured number, and the stated range ends above it.
By their numbers in this assay, from the lowest: compound 4; then compound 3; then compounds 1 and 2 (each within the scatter of the next).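

In this assay, replacing the ring with the open chain bearing an acetate costs far more at this position than changing the ring did, giving a number 63 percentage points lower from compound 1 to compound 4 (beyond the scatter), a number 66 percentage points lower from compound 2 to compound 4 (beyond the scatter) and a number 38 percentage points lower from compound 3 to compound 4 (beyond the scatter). A primary amine alone therefore does not preserve inhibition here: compound 3 keeps part of it on a ring, while compound 4 shows none. Nothing measured here explains this loss.

The ring is lost and the acetate added together in compound 4, so the compounds shown leave open which change matters. An open chain carrying a hydroxyl instead of the acetate, or an azetidine ring carrying an acetate, would separate the two.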